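The source may report more compounds than this note shows. Statements on the series, on what has been measured and on what is new or still open speak of the compounds shown alone.

Series notes. Compound 1 `O=C(CSc1nc(Nc2ccccc2)c2ccccc2n1)Nc1ccccc1F` gives 12400 nM in a functional assay on PC-3 cells (Homo sapiens) for inhibition, read by MTT assay, with a stated time of 72 h; a higher number here means a weaker inhibitor, a lower number a stronger inhibitor; compound 2 `O=C(CSc1nc(Nc2ccccc2)c2ccccc2n1)Nc1cccc(Cl)c1` gives 12600 nM; compound 3 `CCc1cccc(NC(=O)CSc2nc(Nc3ccccc3)c3ccccc3n2)c1` gives 11000 nM, the lowest of the three numbers, though its separations from compound 1 and from compound 2 both sit inside the scatter. Compound 4 `COc1cccc(NC(=O)CSc2nc(Nc3ccccc3)c3ccccc3n2)c1` is not yet measured; it differs from compound 3 by methoxy in place of ethyl on an aromatic carbon. The measured steps that bear on this are all flat: a 1.1-fold lower number from compound 2 to compound 3 (0.06 log units; within the scatter), a 1.1-fold lower number from compound 1 to compound 3 (0.05 log units; within the scatter) and a 1.0-fold higher number from compound 1 to compound 2 (0.01 log units; within the scatter), so changes on this ring have so far produced nothing beyond the scatter in this assay. For compound 4 no step beyond the scatter is therefore expected, a 1.0-fold higher number from compound 3 to compound 4 (0.02 log units; within the scatter). Compound 4 is estimated at 11500 nM, with a range from 6000 nM to 22000 nM.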

Compound 4, half-maximal inhibitory concentration: 11600 nM
Estimate against measurement, compound 4: 1.0-fold (0.00 log units) below; the range from low to high includes it.
By their numbers in this assay, from the lowest: compounds 3, 4, 1 and 2 (each within the scatter of the next).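

With methoxy, a hydrogen-bond acceptor enters this position without any shift beyond the scatter in this assay, since methoxy in place of ethyl gives a 1.1-fold higher number from compound 3 to compound 4 (0.02 log units; within the scatter) and methoxy in place of chloro gives a 1.1-fold lower number from compound 2 to compound 4 (0.04 log units; within the scatter). 3-Methoxyphenyl in place of 2-fluorophenyl on the amide-type nitrogen is just as flat, with a 1.1-fold lower number from compound 1 to compound 4 (0.03 log units; within the scatter). Nothing available explains this flatness.

From the compounds shown here alone, whether an amine or a carboxylic acid on this ring would produce a step beyond the scatter remains open. So does the effect of changes to the shared core.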